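The compounds below may be only part of what the source reports. "The series", "measured", "known", "first", "only" and "open" are said of these compounds alone.

Working notes on the series, all read in a physicochemical assay for solubility, at pH 7.4; on this read-out higher numbers stand for higher solubility and lower numbers for lower solubility. Compound 1 `CN(C)C1(C)CN(c2c(F)cc3c(=O)c(C(=O)O)cn(C4CC4)c3c2F)C1` gives 23.6 ug/mL, compound 2 `CNC1CN(c2c(F)cc3c(=O)c(C(=O)O)cn(C4CC4)c3c2F)C1` gives 1.7 ug/mL, and compound 3 `C[C@H]1N(c2c(F)cc3c(=O)c(C(=O)O)cn(C4CC4)c3c2F)C[C@]1(C)N` gives 3.3 ug/mL. Compound 3 is therefore second of the three numbers, but it cannot be separated from compound 2 and lies well short of compound 1.

The next structure is compound 4 `C[C@H]1[C@@H](N)CN1c1c(F)cc2c(=O)c(C(=O)O)cn(C3CC3)c2c1F`. The change is a group of 6 heavy atoms (4 carbon, 2 nitrogen; one four-membered non-aromatic ring with 1 hetero atom) in place of a group of 7 heavy atoms (5 carbon, 2 nitrogen; one four-membered non-aromatic ring with 1 hetero atom), on an aromatic carbon, and it sits on an aromatic carbon, ortho to two fluoro groups.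

The closest guide is a 1.9-fold higher number from compound 2 to compound 3 (0.29 log units; within the scatter), which is within the scatter and also relates a group of 6 heavy atoms to a group of 7 heavy atoms. The other two steps both start from compound 1: a 14-fold lower number from compound 1 to compound 2 (1.14 log units; beyond the scatter) is large and a 7.2-fold lower number from compound 1 to compound 3 (0.85 log units; beyond the scatter) is modest. Both involve the group of 8 heavy atoms, which neither compound 3 nor compound 4 carries, so they bear on this step only weakly. Within the data shown here, no measured step has this exact pair of groups, which leaves the range fairly wide.

No step beyond the scatter is expected in this assay. The estimated step is a 1.2-fold lower number from compound 3 to compound 4 (0.07 log units; within the scatter). For compound 4 the expected value is 2.8 ug/mL, with an estimated range of 1.1 ug/mL to 7.5 ug/mL.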

Compound 4, solubility: 23.6 ug/mL
Compound 4: middle estimate off by 8.4-fold (0.93 log units), on the low side; measured number above the stated range.
By their numbers in this assay, from the lowest: compounds 2 and 3 (each within the scatter of the next); then compounds 1 and 4 (each within the scatter of the next).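

In this assay, the high end of the series no longer belongs only to the group of 8 heavy atoms on this aromatic carbon, ortho to two fluoro groups: exchanging that group for the group of 6 heavy atoms gives no change at the digits printed from compound 1 to compound 4 (within the scatter) here. Heavy-atom count alone does not order these numbers, since two groups of 6 heavy atoms with the same counted ring, donors and acceptors are separated by a 14-fold higher number from compound 2 to compound 4 (1.14 log units; beyond the scatter) and the group of 7 heavy atoms lies apart from the entering group by a 7.2-fold higher number from compound 3 to compound 4 (0.85 log units; beyond the scatter) in this series. Nothing available on these compounds accounts for the result.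

The compounds shown leave open whether the number seen with the entering group depends on its particular arrangement at the 2 defined stereocentres, which would need the other stereoisomers of that group to settle. They also leave open whether an ethyl or a hydroxyl on the four-membered ring would keep the number with the high pair or move it toward the low pair.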